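N-Demethylation of a Benzylic Amine on a GPR88 Agonist Scaffold

This account rests on a few compounds, and the source may have more. Where it says the series, first, only, none or still open, it means among the compounds named here.

Measured so far:
compound 1, `CC[C@H](C)[C@H](N)CN(C(=O)[C@@H]1C[C@H]1c1ccccc1)c1ccc(-c2ccc(Oc3ccccc3)cc2)cc1`, 94 nM
compound 2, `CC[C@H](C)[C@H](N)CN(C(=O)[C@@H]1C[C@H]1c1ccccc1)c1ccc(-c2ccc(CN(C)C)cc2)cc1`, 460 nM

In a functional assay for agonist activity at G protein-coupled receptor 88 (Homo sapiens), read by HTRF and cAMP accumulation (on this read-out higher numbers stand for an effect only at larger amounts of compound and lower numbers for an effect already at smaller amounts), compound 2 gives the higher of the two numbers; its nearest neighbour is compound 1, and the step of a 4.9-fold higher number from compound 1 to compound 2 (0.69 log units; beyond the scatter) separates them. Compound 3, `CC[C@H](C)[C@H](N)CN(C(=O)[C@@H]1C[C@H]1c1ccccc1)c1ccc(-c2ccc(CNC)cc2)cc1`, differs from compound 2 by hydrogen in place of methyl on an amine nitrogen. Among the measured compounds shown here, no measured step concerns this amine nitrogen; the only step in hand, phenoxy to (dimethylamino)methyl, is a different change and says nothing about removing one methyl. Compound 3 is therefore expected to sit near compound 2, with an estimated step of a 1.2-fold lower number from compound 2 to compound 3 (0.06 log units; within the scatter), not beyond the scatter. The estimate for compound 3 in this assay is 400 nM, within 150 nM to 1200 nM.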

Compound 3, half-maximal effective concentration: 6400 nM
Compound 3: middle estimate off by 16-fold (1.20 log units), on the low side; the whole stated range lies below it.
By their numbers in this assay, from the lowest: compound 1; then compound 2; then compound 3.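

In this assay this amine nitrogen proves highly sensitive to a small change: hydrogen in place of methyl gives a 14-fold higher number from compound 2 to compound 3 (1.14 log units; beyond the scatter) and so removes far more than one heavy atom might suggest. With phenoxy as the reference, the (methylamino)methyl group gives a 68-fold higher number from compound 1 to compound 3 (1.83 log units; beyond the scatter) whereas the (dimethylamino)methyl group gave only a 4.9-fold higher number from compound 1 to compound 2 (0.69 log units; beyond the scatter) on the same comparison. Nothing in hand accounts for this loss. Going by these compounds, whether the aminomethyl group, with no methyl left on the nitrogen, sits higher still remains open, as does whether a diethylamino group would match or pass compound 2.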